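Nitro for methoxy on the aryl piperazine of compound 3

The source may report more compounds than this note shows. Statements on the series, on what has been measured and on what is new or still open speak of the compounds shown alone.

Three thiosemicarbazone oxindoles have numbers in a functional assay on MCF7 cells (Homo sapiens) for inhibition, read by MTT assay, with a stated time of 72 h (a lower number here means a stronger inhibitor, a higher number a weaker inhibitor), so far. Compound 1 `O=C1Nc2ccc([N+](=O)[O-])cc2/C1=N/NC(=S)N1CCN(c2ccccc2)CC1` gives 23300 nM in this assay. Compound 2 `O=C1Nc2cccc(Cl)c2/C1=N/NC(=S)N1CCN(c2ccccc2)CC1` gives 52100 nM. Compound 3 `COc1ccc(N2CCN(C(=S)N/N=C3\C(=O)Nc4ccc(Cl)cc43)CC2)cc1` gives 13800 nM, the lowest of the three; its gap to compound 1 is within the scatter, so no order between those two can be read, while its gap to compound 2 lies beyond the scatter. No two of these compounds differ in a single place, so none of the gaps is tied to one structural change.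

The next compound, compound 4 `O=C1Nc2ccc(Cl)cc2/C1=N/NC(=S)N1CCN(c2ccc([N+](=O)[O-])cc2)CC1`, is not yet measured. Relative to compound 3 the change is nitro in place of methoxy on an aromatic carbon, on the aromatic carbon para to a large group; cut one bond further out it reads 4-methoxyphenyl to 4-nitrophenyl. Going by the values given here, nothing among the measured compounds carries a nitro group at this place, so the step has no precedent.

The expectation for compound 4 is a step of a 1.3-fold higher number from compound 3 to compound 4 (0.12 log units; within the scatter), which is estimated to stay within the scatter, leaning weaker if anything. Compound 4 is expected to give about 18000 nM in this assay, estimated between 7000 nM and 45000 nM.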

Compound 4, half-maximal inhibitory concentration: 20900 nM
Compound 4: the middle estimate sits 1.2-fold (0.06 log units) below what was measured; the range from low to high includes it.
By their numbers in this assay, from the lowest: compounds 3, 4 and 1 (each within the scatter of the next); then compound 2.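

In this assay, going by these compounds alone, the exchange of methoxy for nitro on the aromatic carbon para to a large group gives a 1.5-fold higher number from compound 3 to compound 4 (0.18 log units; within the scatter), the first step that can be tied to a single place. That step lies within the scatter, so no order can be read between compound 3 and compound 4, and on this shared core the 4-methoxyphenyl and 4-nitrophenyl forms cannot be told apart in this measurement. No accompanying measurement bears on why the two groups read alike.

On these data alone, whether an amine or a carboxylic acid on this same aromatic carbon would give a step beyond the scatter stays open, as one exchange at one position says little about how far the number can move there. Also open, as far as these compounds go, is how an aryl piperazine without a substituent would compare with these two groups on the core of compound 3, as neither compound 1 nor compound 2 differs from compound 3 or compound 4 in one place only.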